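This account rests on a few compounds, and the source may have more. Where it says the series, first, only, none or still open, it means among the compounds named here.

Measured so far:
compound 1 `COc1cc(CNCc2ccccc2)ccc1OCc1ccc(Cl)nc1` — 90000 nM
compound 2 `COc1cc(CNCc2ccncc2)ccc1OCc1cnc(Cl)c(Cl)c1` — 220 nM

In a functional assay on HeLa cells (Homo sapiens) for inhibition, with a stated time of 72 h (a lower number here means that less compound is needed, a higher number that more compound is needed for the effect), compound 1 gives 90000 nM, the higher of the two numbers here; compound 2 gives 220 nM, a gap well beyond the scatter. Compound 2 differs from compound 1 in more than one place, so no single step can be read from that pair.

Compound 3 `COc1cc(CNCCCN(C)C)ccc1OCc1ccc(Cl)nc1` differs from compound 1 by 2-(dimethylamino)ethyl in place of phenyl on a saturated chain carbon bound to an amine nitrogen. Among the compounds with values here, no comparable step is measured, so the direction is open. A step near the scatter, from compound 1 to compound 3, is expected: a 1.5-fold lower number from compound 1 to compound 3 (0.18 log units; within the scatter). Compound 3 is expected at about 60000 nM, within 15000 nM to 200000 nM.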

Compound 3, half-maximal effective concentration: 5000 nM
Beside the measured number, compound 3's estimate is 12-fold (1.08 log units) above it; the whole stated range lies above it.
By their numbers in this assay, from the lowest: compound 2; then compound 3; then compound 1.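

At this saturated chain carbon bound to an amine nitrogen, the choice of group matters in this assay: 2-(dimethylamino)ethyl in place of phenyl gives an 18-fold lower number from compound 1 to compound 3 (1.26 log units; beyond the scatter) on the shared core. Within the data shown here, this is the first single change readable, and it shows that a group with no ring can stand here with a lower number than phenyl. Nothing measured here accounts for the step.

As far as these compounds go, whether the step follows the terminal dimethylamino nitrogen or the loss of the phenyl ring remains open. A plain butyl chain or a 2-(pyrrolidin-1-yl)ethyl group at this place would bear on that question.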